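Benzyl exchange on compound 1: notes toward compound 4

The source may hold more compounds than are shown below. What is called first, only, known or untested is meant among the compounds shown, and "the series" means these compounds.

Of the compounds shown here, three have numbers so far in a functional assay on MDA-MB-231 cells (Homo sapiens) for cytotoxicity, read by MTT assay, with a stated time of 24 h (on this read-out lower numbers stand for stronger inhibition and higher numbers for weaker inhibition), and the spread is modest. Compound 1 `Cc1ccc(/C=C2\CN(Cc3cn(Cc4ccc(F)cc4)nn3)C/C(=C\c3ccc(C)cc3)C2=O)cc1` gives 26800 nM as its value, the second highest of the three. Compound 2 `O=C1/C(=C/c2ccccc2F)CN(Cc2cn(Cc3ccc(F)cc3)nn2)C/C1=C\c1ccccc1F` lies lower with 10000 nM as its value, and compound 3 `COc1ccc(/C=C2\CN(Cc3cn(Cc4ccccc4F)nn3)C/C(=C\c3ccc(OC)cc3)C2=O)cc1` lies higher with 67200 nM as its value. Both gaps from compound 1 lie beyond the scatter.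

For the measured compounds named here, still unmeasured is compound 4 `Cc1ccc(/C=C2\CN(Cc3cn(Cc4ccccc4Cl)nn3)C/C(=C\c3ccc(C)cc3)C2=O)cc1`, which keeps the core of compound 1 and carries 2-chlorophenyl in place of 4-fluorophenyl on a saturated chain carbon bound to an aromatic nitrogen as its only change. Going by the values given here, no two measured compounds differ in one place only, so the data give no direct reading of this exchange. No step beyond the scatter is therefore expected in this assay, and no direction is assigned. The estimated change is a 1.1-fold lower number from compound 1 to compound 4 (0.05 log units; within the scatter) in size. For compound 4 the expected value is 24000 nM within an estimated range of 9000 nM to 60000 nM on this read-out.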

Compound 4, half-maximal inhibitory concentration: 29000 nM
For compound 4 the middle estimate is 1.2-fold (0.08 log units) below the measured one; measured number inside the range.
By their numbers in this assay, from the lowest: compound 2; then compounds 1 and 4 (each within the scatter of the next); then compound 3.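

In this assay, 2-chlorophenyl in place of 4-fluorophenyl on a saturated chain carbon bound to an aromatic nitrogen gives a 1.1-fold higher number from compound 1 to compound 4 (0.03 log units; within the scatter) and is the only one-place comparison shown in the series. The step lies within the scatter, so on the core of compound 1 the 4-fluorobenzyl and 2-chlorobenzyl groups cannot be told apart on this read-out. No measured property bears on this result, and no cause can be assigned to it.

The exchange changes the halogen and its place on the ring together, so the compounds shown do not separate the two. Also open, as far as these compounds go, is whether a carboxylic acid or a longer chain ending in an amine at this place would give a step beyond the scatter in this assay on this core.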